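Swapping Five-Membered Heteroaryl Groups on a Shared Core

The compounds below may be only part of what the source reports. "The series", "measured", "known", "first", "only" and "open" are said of these compounds alone.

Going by the values given here, compound 3 `COC(=O)c1nc(-c2ccsc2)n(-c2ccc(F)cc2)n1` gives 10700 nM in a functional assay on NPC-TW01 cells (Homo sapiens) for inhibition, read by MTT assay, with a stated time of 72 h (a lower number here means a stronger inhibitor of growth, a higher number a weaker inhibitor of growth), the lowest of the three numbers so far, though both neighbours sit within the scatter of it: compound 2 `COC(=O)c1nc(-c2ccoc2)n(-c2ccc(F)cc2)n1` gives 11700 nM and compound 1 `COC(=O)c1nc(C)n(-c2ccc(F)cc2)n1` gives 15200 nM. The step of a 1.4-fold lower number from compound 1 to compound 3 (0.15 log units; within the scatter) and the step of a 1.1-fold lower number from compound 2 to compound 3 (0.04 log units; within the scatter) both stayed within the scatter, as did a 1.3-fold lower number from compound 1 to compound 2 (0.11 log units; within the scatter). Compound 4 `COC(=O)c1nc(-c2ccc[nH]2)n(-c2ccc(F)cc2)n1` differs from compound 3 by 1H-pyrrol-2-yl in place of thiophen-3-yl on an aromatic carbon. Because the earlier heteroaryl exchange a 1.1-fold lower number from compound 2 to compound 3 (0.04 log units; within the scatter) moved nothing beyond the scatter, no step beyond the scatter is expected in this assay for compound 4 either. Compound 4 is therefore estimated at 11000 nM, with a range from 5000 nM to 25000 nM. The expected step is a 1.0-fold higher number from compound 3 to compound 4 (0.01 log units; within the scatter).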

Compound 4, concentration for 50% growth inhibition: 9580 nM
Beside the measured number, compound 4's estimate is 1.1-fold (0.06 log units) above it; the range from low to high includes it.
By their numbers in this assay, from the lowest: compounds 4, 3, 2 and 1 (each within the scatter of the next).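

The entering 1H-pyrrol-2-yl carries a hydrogen-bond donor where thiophen-3-yl carries none, yet in this assay the exchange gives only a 1.1-fold lower number from compound 3 to compound 4 (0.05 log units; within the scatter). The other two steps, a 1.2-fold lower number from compound 2 to compound 4 (0.09 log units; within the scatter) and a 1.6-fold lower number from compound 1 to compound 4 (0.20 log units; within the scatter), also stay within the scatter, so this assay does not separate any of the four groups at this position, methyl included. Nothing available explains this flat result. The compounds shown leave open whether an amine, a carboxylic acid or a longer alkyl chain here would move the number beyond the scatter. They also leave open what changes at the methoxycarbonyl and 4-fluorophenyl groups would do, since both stay fixed throughout.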